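Trimming a methoxy group in a small cytotoxicity series

The source may report more compounds than this note shows. Statements on the series, on what has been measured and on what is new or still open speak of the compounds shown alone.

compound 1 `COc1cc(-c2cc(/C=C/C(=O)c3ccc(Cl)c(Cl)c3)[nH]n2)cc(OC)c1OC`: 96%
compound 2 `COc1ccc(C(=O)/C=C/c2cc(-c3cc(OC)c(OC)c(OC)c3)n[nH]2)cc1OC`: 95%

In a functional assay on NCI/ADR-RES cells (Homo sapiens) for cytotoxicity, read by sulforhodamine B assay, with a stated time of 48 h, tested at 0.1 uM (on this read-out lower numbers stand for a stronger effect and higher numbers for a weaker effect at the one concentration tested), compound 1 gives 96% and compound 2 gives 95%. Going by the values given here, compound 2 stands beside compound 1, the only other number, and the step of a number 1 percentage points lower from compound 1 to compound 2 (within the scatter) lies within the scatter. Compound 3 `COc1ccc(C(=O)/C=C/c2cc(-c3cc(OC)c(OC)c(OC)c3)n[nH]2)cc1` differs from compound 2 by hydrogen in place of methoxy on an aromatic carbon. Among the compounds with values here, no measured step removes a methoxy; the one measured step, 3,4-dimethoxyphenyl in place of 3,4-dichlorophenyl on a carbonyl carbon, stayed within the scatter. Hence no step beyond the scatter is expected: a number 1 percentage points lower from compound 2 to compound 3 (within the scatter). Compound 3 is expected to give 94%, between 82% and 102%.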

Compound 3, a percentage reported as activity, at one concentration (the size of the read-out at that concentration, not a potency): 97%
Estimate against measurement, compound 3: 3 percentage points below, and the stated range covers the measured number.
By their numbers in this assay, from the lowest: compounds 2, 1 and 3 (each within the scatter of the next).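

In this assay cutting 3,4-dimethoxyphenyl to 4-methoxyphenyl gives a number 2 percentage points higher from compound 2 to compound 3 (within the scatter) so this methoxy, ortho to a methoxy group, can go with no step beyond the scatter at the one concentration tested. Set against the 3,4-dichlorophenyl on a carbonyl carbon, the 4-methoxyphenyl gives a number 1 percentage points higher from compound 1 to compound 3 (within the scatter) and so all three groups at this place read alike. No measured evidence offers a cause for this.

On these data alone, with only this single concentration, it stays open whether any group at this aromatic carbon separates from the others. A hydroxy group or an amine there would test that.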